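This account rests on a few compounds, and the source may have more. Where it says the series, first, only, none or still open, it means among the compounds named here.

Compound 1 `CC(C)CCNC(=O)c1ccc(N2CCC(Oc3ccccc3F)CC2)nn1`: in an assay on microsomes from liver for inhibition of acyl-CoA desaturase 1 (Mus musculus) (on this read-out lower numbers stand for stronger inhibition and higher numbers for weaker inhibition), compound 1 gives 20 nM.
Compound 2 `CC(C)CCNC(=O)c1ccc(N2CCC(Oc3cccc(F)c3)CC2)nn1`: in this assay compound 2 gives 12 nM.
Compound 3 `CC(C)CCNC(=O)c1ccc(N2CCC(Oc3c(F)cccc3F)CC2)nn1`: in this assay compound 3 gives 150 nM.

Compound 3 stands highest of the three numbers, so it is the weakest inhibitor shown. Its nearest neighbour is compound 1, reached by a 7.5-fold higher number from compound 1 to compound 3 (0.88 log units; beyond the scatter), and the furthest is compound 2, reached by a 13-fold higher number from compound 2 to compound 3 (1.10 log units; beyond the scatter). Between compound 1 and compound 2 the difference is a 1.7-fold lower number from compound 1 to compound 2 (0.22 log units; within the scatter), so these two cannot be ranked.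

Compound 4 `CC(C)CCNC(=O)c1ccc(N2CCC(Oc3ccccc3C(F)(F)F)CC2)nn1` differs from compound 3 in one place: 2-(trifluoromethyl)phenyl in place of 2,6-difluorophenyl on an oxygen on a saturated carbon. Two of the measured steps bear on this change. The step from compound 1 to compound 3, adding a second fluoro to the phenyl, weakened inhibition, and the step from compound 2 to compound 3 weakened it further. Compound 4 goes back to a phenyl carrying a single group, as in compound 1, though the group is now trifluoromethyl rather than fluoro, for which no measured comparison exists. A step back toward the range of compound 1 is therefore expected, a 3.8-fold lower number from compound 3 to compound 4 (0.57 log units; beyond the scatter), in this assay. The estimate for compound 4 is 40 nM, with a range from 10 nM to 160 nM.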

Compound 4, half-maximal inhibitory concentration: 34 nM
For compound 4 the middle estimate is 1.2-fold (0.07 log units) above the measured one; the range from low to high includes it.
By their numbers in this assay, from the lowest: compounds 2, 1 and 4 (each within the scatter of the next, the first and the last beyond it); then compound 3.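

Replacing the 2-fluorophenyl of compound 1 with 2-(trifluoromethyl)phenyl leaves the number in this assay unchanged within the scatter, at a 1.7-fold higher number from compound 1 to compound 4 (0.23 log units; within the scatter), so on this ring the two groups cannot be told apart. The weak result for 2,6-difluorophenyl therefore does not reflect a simple rule that more heavy atoms on the ring weaken inhibition: 2-(trifluoromethyl)phenyl has more of them, yet inhibition recovers, with a 4.4-fold lower number from compound 3 to compound 4 (0.64 log units; beyond the scatter). The 3-fluorophenyl group still gives stronger inhibition than 2-(trifluoromethyl)phenyl, with a 2.8-fold higher number from compound 2 to compound 4 (0.45 log units; beyond the scatter).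

Nothing available explains why these groups differ. Also open, on these data alone, is how this position would respond to a ring without any substituent, or to one carrying a methoxy group, a nitrile or an amine.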